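This account rests on a few compounds, and the source may have more. Where it says the series, first, only, none or still open, it means among the compounds named here.

Measured so far in a functional assay on U-937 cells (Homo sapiens) for cytotoxicity, read by MTT assay, with a stated time of 24 h; a lower number here means a stronger inhibitor, a higher number a weaker inhibitor:
- compound 1 `C=CCOc1c(Br)cc(Br)cc1Oc1ccc(Br)cc1Br`: 29 ug/mL
- compound 2 `Brc1ccc(Oc2cc(Br)cc(Br)c2OCc2ccccc2)c(Br)c1`: 29 ug/mL
- compound 3 `COc1c(Br)cc(Br)cc1Oc1ccc(Br)cc1Br`: 34.5 ug/mL

Compound 3 gives the highest of the three numbers, but the steps to it are small: a 1.2-fold higher number from compound 1 to compound 3 (0.08 log units; within the scatter) and a 1.2-fold higher number from compound 2 to compound 3 (0.08 log units; within the scatter), both within the scatter, so no order among compounds 1, 2 and 3 can be read from them. The step of no change at the digits printed from compound 1 to compound 2 (within the scatter) likewise shows nothing beyond the scatter.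

Compound 4 `C#CCOc1c(Br)cc(Br)cc1Oc1ccc(Br)cc1Br` is not yet measured. Its change from compound 3 is ethynyl in place of hydrogen on a saturated chain carbon bound to an oxygen on an aromatic ring. Within the data shown here, the steps that bear on it are the same place being varied in the opposite sense: hydrogen to vinyl, read backwards from a 1.2-fold higher number from compound 1 to compound 3 (0.08 log units; within the scatter), and hydrogen to phenyl, read backwards from a 1.2-fold higher number from compound 2 to compound 3 (0.08 log units; within the scatter). Both were flat. A third substituent of two heavy atoms on the same saturated chain carbon is therefore expected to leave the number where it stands, with a 1.1-fold lower number from compound 3 to compound 4 (0.05 log units; within the scatter) expected to fall within the scatter. The estimate for compound 4 is 31 ug/mL, range 15 ug/mL to 62 ug/mL.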

Compound 4, half-maximal inhibitory concentration: 29.5 ug/mL
Compound 4: the middle estimate sits 1.1-fold (0.02 log units) above what was measured, within the range that was stated.
By their numbers in this assay, from the lowest: compounds 1, 2, 4 and 3 (each within the scatter of the next).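

Ethynyl on the saturated chain carbon bound to an oxygen on an aromatic ring, the methoxy to propargyloxy change, is the first triple bond at this position, and in this readout (this assay) it gives a step within the scatter (a 1.2-fold lower number from compound 3 to compound 4 (0.07 log units; within the scatter)). Direct comparison with the other two groups at this position is also flat, against phenyl (a 1.0-fold higher number from compound 2 to compound 4 (0.01 log units; within the scatter)) and against vinyl (a 1.0-fold higher number from compound 1 to compound 4 (0.01 log units; within the scatter)), so across compounds 1 to 4, with none going against it, this position shows no response to triple bond, double bond or phenyl ring. No measurement on hand accounts for this flatness.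

From the compounds shown here alone, whether the flat response extends to an amine, a carboxylic acid or a longer chain at this position remains open. So does the response to replacing the bromine atoms on the shared core.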